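Two Amides at the Ceiling and an Untested Urea

This account rests on a few compounds, and the source may have more. Where it says the series, first, only, none or still open, it means among the compounds named here.

Measured in an ADME assay on NCI-H460 cells (Homo sapiens) for cytotoxicity, read by MTT assay, with a stated time of 72 h; on this read-out higher numbers stand for weaker inhibition and lower numbers for stronger inhibition:
Compound 1 `COc1ccc(C(=O)Nc2ccccc2-c2nnn(-c3ccc(OC)cc3)n2)cc1`: > 100000 nM
Compound 2 `COc1cccc(-n2nnc(-c3ccccc3NC(=O)c3ccc(NC(C)=O)cc3)n2)c1`: > 100000 nM

Compound 1 has no number, only (the limit of > 100000 nM in this assay, at which 2 of the 2 values shown sit). Compound 3 `COc1ccc(NC(=O)Nc2ccccc2-c2nnn(-c3ccc(OC)cc3)n2)cc1` carries (4-methoxyphenyl)amino in place of 4-methoxyphenyl on a carbonyl carbon. For the measured compounds named here, both known results are limits, and no measured step gives a size for this change. The expected change in this assay, an at least 1.2-fold lower number from compound 1 to compound 3 (0.09 log units; that floor lies within the scatter), is not expected to go beyond the usual scatter, and no firm direction can be given. Compound 3 is estimated at 80000 nM, with an expected range of 25000 nM to 100000 nM.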

Compound 3, half-maximal inhibitory concentration: 52500 nM
Compound 3: the middle estimate sits 1.5-fold (0.18 log units) above what was measured, and the stated range covers the measured number.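

In this assay, for the compounds shown here, compound 3 gives the first reading at this position that is a number and not a limit. Placing (4-methoxyphenyl)amino in place of 4-methoxyphenyl on a carbonyl carbon gives an at least 1.9-fold lower number from compound 1 to compound 3 (0.27 log units; that floor lies within the scatter), so the change now has a stated floor, although that floor does not clear the scatter. The other readings shown are still limits: the limit of > 100000 nM in this assay, at which 2 of the 3 values shown sit.

From the compounds shown here alone, the full size of this step stays open, as its starting point is only a limit. Also open, going by these compounds, is how a benzylamino group or a morpholine on that carbonyl carbon would read.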